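The source may report more compounds than this note shows. Statements on the series, on what has been measured and on what is new or still open speak of the compounds shown alone.

In a functional assay on HeLa cells (Homo sapiens) for cytotoxicity, read by ELISA, with a stated time of 4 days (a higher number here means a weaker inhibitor, a lower number a stronger inhibitor), compound 1 `Cc1ccsc1-c1cc(-c2ccoc2)cc(-c2ccco2)n1` gives 30500 nM and compound 2 `Cc1ccsc1-c1cc(-c2ccc(Cl)o2)cc(-c2ccco2)n1` gives 22200 nM. These two numbers lie within the usual scatter of each other, so compound 2 stands level with compound 1. Among the measured compounds shown here, the only measured step is the change to 5-chlorofuran-2-yl in place of furan-3-yl, which gives a 1.4-fold lower number from compound 1 to compound 2 (0.14 log units; within the scatter). Compound 3 `Cc1ccsc1-c1cc(-c2ccc(Cl)o2)cc(-c2cccc(Cl)c2)n1` keeps the 5-chlorofuran-2-yl group of compound 2 but carries 3-chlorophenyl in place of furan-2-yl, next to the ring nitrogen: 3-chlorophenyl in place of furan-2-yl on an aromatic carbon. For the measured compounds named here, no measured step covers this change, so the one step available is only a loose guide. In this assay, no step beyond the scatter is therefore expected, in either direction. The estimated step is a 1.2-fold lower number from compound 2 to compound 3 (0.09 log units; within the scatter). For compound 3, the estimated value is 18000 nM, with an expected range of 7000 nM to 45000 nM.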

Compound 3, half-maximal inhibitory concentration: 24800 nM
For compound 3 the middle estimate is 1.4-fold (0.14 log units) below the measured one; the range from low to high includes it.
By their numbers in this assay, from the lowest: compounds 2, 3 and 1 (each within the scatter of the next).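

Among the compounds shown here, the earlier step changed the group at another place on the core, whereas compound 3 gives the first reading at the aromatic carbon next to the ring nitrogen. In this assay, replacing furan-2-yl with 3-chlorophenyl exchanges a five-membered ring holding one hydrogen-bond acceptor for a six-membered carbon ring bearing chlorine, yet the result is a 1.1-fold higher number from compound 2 to compound 3 (0.05 log units; within the scatter), so this sizeable change in structure leaves the number level. No measurement available here explains this lack of change.

From the compounds shown here alone, both groups seen at this position are uncharged aromatic rings, so it remains open whether an amine, a carboxylic acid or a longer alkyl chain there would shift the number beyond the scatter. A single step also cannot show whether the same swap would behave alike with furan-3-yl in place of the 5-chlorofuran-2-yl group.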